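The source may report more compounds than this note shows. Statements on the series, on what has been measured and on what is new or still open speak of the compounds shown alone.

Measured compounds:

Compound 1 `COc1ccc(-c2cn3ccnc3c(-c3ccc4ncn(C5CCCCC5)c4c3)n2)cc1` gives 65.2% in a functional assay on UACC-62 cells (Homo sapiens) for inhibition, read by sulforhodamine B assay, with a stated time of 48 h, tested at 10 uM; on this read-out lower numbers stand for less inhibition and higher numbers for more inhibition at the one concentration tested (going by the name of the read-out).
Compound 2 `COc1ccccc1-c1cn2ccnc2c(-c2ccc3ncn(C4CCCCC4)c3c2)n1` gives 25.1%.

Compound 1 stands highest of the two numbers measured; its nearest neighbour is compound 2, reached by the step of a number 40.1 percentage points lower from compound 1 to compound 2 (beyond the scatter), which is 2-methoxyphenyl in place of 4-methoxyphenyl on an aromatic carbon. Compound 3 `c1csc(-c2cn3ccnc3c(-c3ccc4ncn(C5CCCCC5)c4c3)n2)c1` has not yet been measured. It differs from compound 1 as follows: thiophen-2-yl in place of 4-methoxyphenyl on an aromatic carbon. Within the data shown here, no measured step covers a thiophen-2-yl group, so the one known step only shows that this position of the shared core responds strongly to a change of the attached aryl group, without indicating the direction for a five-membered ring. A modest decrease is therefore expected, with wide uncertainty, a number 20.2 percentage points lower from compound 1 to compound 3 (beyond the scatter). Compound 3 is estimated at 45%, within a range from 15% to 75%.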

Compound 3, a percentage reported as inhibition, at one concentration (the size of the read-out at that concentration, not a potency): 24.8%
Compound 3: middle estimate off by 20.2 percentage points, on the high side, and the stated range covers the measured number.
By their numbers in this assay, from the lowest: compounds 3 and 2 (each within the scatter of the next); then compound 1.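

In this assay, this position now shows a second large step, and this one replaces the whole 4-methoxyphenyl group with a five-membered aromatic ring: a number 40.4 percentage points lower from compound 1 to compound 3 (beyond the scatter). Two quite different groups, 2-methoxyphenyl and thiophen-2-yl, give values that cannot be told apart, with a number 0.3 percentage points lower from compound 2 to compound 3 (within the scatter), so among these three compounds only the 4-methoxyphenyl group of compound 1 stands apart. Nothing at hand gives a reason for this.

The compounds shown leave open whether the higher value of compound 1 belongs to the methoxy group itself or to the phenyl ring that carries it. An unsubstituted phenyl, a 3-methoxyphenyl or a 4-aminophenyl group at this position would help to separate these two readings.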